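This account rests on a few compounds, and the source may have more. Where it says the series, first, only, none or still open, it means among the compounds named here.

Measured so far:
- compound 1, `CN1C[C@@H]2[C@H](C1)[C@H]2CN(Cc1cccc(OC(F)(F)F)c1)C(=O)c1cn(C)cn1`: 0.455 h
- compound 2, `CCN1C[C@@H]2[C@H](C1)[C@H]2CN(Cc1cccc(Cl)c1)C(=O)c1cn(C)cn1`: 1.05 h

In an in vitro ADME assay on microsomes (Homo sapiens) for metabolic stability (a higher number here means that the compound lasts longer, a lower number that the compound disappears faster), compound 2 gives the higher of the two numbers, and compound 1 gives the lower, a gap that is beyond the usual scatter. Going by the values given here, the two compounds differ in more than one place, so no single step between them can be read from these values.

Compound 3, `CN1C[C@@H]2[C@H](C1)[C@H]2CN(Cc1cccc(Cl)c1)C(=O)c1cn(C)cn1`, has not been measured yet. It comes from compound 2 by a change at the amine nitrogen in the ring: hydrogen in place of methyl on a saturated chain carbon bound to an amine nitrogen in a ring. Cut one bond further out, the same change reads ethyl to methyl. Among the compounds with values here, no measured pair shows that change on its own; compound 1 carries the methyl, but with a different group on the benzyl ring as well.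

With nothing to anchor it, a small step downward is expected for compound 3, close to the edge of the scatter, as a 1.5-fold lower number from compound 2 to compound 3 (0.18 log units; within the scatter). Compound 3 is estimated at 0.7 h in this assay, with a range from 0.35 h to 1.4 h.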

Compound 3, half-life: > 2 h
Compound 3: a limit, no number; the forecaster's own chance of this, stated with the estimate: 5%; at least 2.8-fold (0.45 log units) between middle value and limit.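

In this assay compound 3 gives > 2 h, which is a limit of the assay and not a number. At the amine nitrogen in the ring, the change from ethyl to methyl now has its first reading, an at least 1.9-fold higher number from compound 2 to compound 3 (0.27 log units; that floor lies within the scatter): the direction is toward longer survival, but the floor alone does not separate the pair, so a real gain from this change is not yet established. The series also gains its first single-change reading on an aromatic carbon, chloro in place of trifluoromethoxy, with methyl on the amine nitrogen in both compounds, and this one, an at least 4.3-fold higher number from compound 1 to compound 3 (0.64 log units; beyond the scatter), clears the scatter even as a floor, making it the firmer of the two steps.

From the compounds shown here alone, how far either step really reaches stays open, as both rest on the same value: the limit of > 2 h in this assay, at which 1 of the 3 values shown sits. Also open, going by these compounds, is how a hydrogen or a longer chain such as propyl on the amine nitrogen in the ring, or a fluoro or a nitrile on the aromatic carbon, would compare with compound 3 in this assay.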